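The compounds below may be only part of what the source reports. "The series", "measured", "known", "first", "only" and "open" are said of these compounds alone.

Measured compounds:
compound 1 `CNC(=O)c1cc(C(=O)NCCC2CCOCC2)cn(Cc2ccccc2)c1=O` with 3.6
compound 2 `CNC(=O)c1cccn(Cc2ccccc2)c1=O` with 3
compound 3 `CNC(=O)c1cc(C(=O)NC2CC2)cn(CC2CCCCC2)c1=O` with 4

In a physicochemical assay for lipophilicity, at pH 7.4 (on this read-out higher numbers stand for higher lipophilicity and lower numbers for lower lipophilicity), compound 3 gives the highest of the three numbers: it lies above compound 1 by a gap beyond the scatter, and further above compound 2, again beyond the scatter. Compound 4 `CNC(=O)c1cc(C(=O)NC2CC2)cn(CC2CCOCC2)c1=O` differs from compound 3 in one place: oxan-4-yl in place of cyclohexyl on a saturated chain carbon bound to an aromatic nitrogen. Going by the values given here, no pair of measured compounds shows this same change, so the expectation rests on the change itself rather than on a measured step. For compound 4 a step of a number 1.00 log units lower from compound 3 to compound 4 (beyond the scatter) is expected in this assay, downward and beyond the scatter. Compound 4 is therefore estimated at 3, with a range from 2.6 to 3.5.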

Compound 4, distribution coefficient: 1.5
The estimate for compound 4 lay 1.50 log units above the measured number; the measured number lies below the stated range.
By their numbers in this assay, from the lowest: compound 4; then compound 2; then compound 1; then compound 3.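

In this assay, oxan-4-yl in place of cyclohexyl on a saturated chain carbon bound to an aromatic nitrogen gives a number 2.50 log units lower from compound 3 to compound 4 (beyond the scatter) and this is a large step. Going by these compounds alone, the earlier compounds contained no pair with this change, so this is the first sign that this place responds strongly to swapping one ring carbon for oxygen. Nothing measured here accounts for the size of the step. The compounds shown leave open whether piperidin-4-yl in the same place would give a step of similar size. They also leave open whether a longer chain would alter this step.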